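Replacing 2,6-difluorophenyl on the amide-type nitrogen of compound 3

A few compounds are considered here, and "the series" means these few. Any claim that something is new, unique, unknown or untested is made for them only; others in the source may bear on it.

Compound 1 `Cc1cc(C(=O)Nc2ccccc2)nn1Cc1cc(Cl)ccc1OCc1ccccc1` gives > 3.7 as a limit of the assay
Compound 2 `Cc1cc(C(=O)Nc2ccc(F)cc2)nn1Cc1cc(Cl)ccc1OCc1ccccc1` gives 3
Compound 3 `Cc1cc(C(=O)Nc2c(F)cccc2F)nn1Cc1cc(Cl)ccc1OCc1ccccc1` gives 3.7

These values come from a physicochemical assay for lipophilicity, at pH 7.4 (on this read-out lower numbers stand for lower lipophilicity and higher numbers for higher lipophilicity), and the compounds share one core. Compound 3 holds the higher of the two actual numbers (3.7), and compound 2 sits lower (3). Compound 1 reports only a limit (> 3.7) and no number.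

Compound 4 `Cc1cc(C(=O)NCc2ccccn2)nn1Cc1cc(Cl)ccc1OCc1ccccc1` differs from compound 3 by (pyridin-2-yl)methyl in place of 2,6-difluorophenyl on an amide-type nitrogen. The measured steps bear on this only in part, as each keeps a phenyl on that nitrogen. They are a number at least 0.70 log units lower from compound 1 to compound 2 (beyond the scatter) and a number 0.70 log units higher from compound 2 to compound 3 (beyond the scatter), while a number no higher from compound 1 to compound 3 (the limit leaves the size open) leaves its size open. None of them brings in a ring with a hetero atom, so the swap in compound 4 is a larger edit than any of these. With compound 2 (3) as the lowest measured point, a number near that level is expected. The expected move is a number 0.80 log units lower from compound 3 to compound 4 (beyond the scatter), modest and beyond the scatter. For compound 4 the estimated value is 2.9 (expected range 2.4 to 3.4).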

Compound 4, distribution coefficient: > 3.7
Compound 4 gave a limit, no number (the forecaster's own chance of this, stated with the estimate: 5%); middle value at least 0.80 log units from the limit.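

In this assay compound 4 reports only a limit, > 3.7, so this change gives no actual number. Even so, the result is a number no lower from compound 3 to compound 4 (the limit leaves the size open), and it is also a number at least 0.70 log units higher from compound 2 to compound 4 (beyond the scatter); the earlier compounds carried only phenyl groups, with or without fluoro, on the amide-type nitrogen, and this result shows that (pyridin-2-yl)methyl, with its ring hetero atom and its hydrogen-bond acceptor, does not bring the read-out down on this shared core. The step between compound 1 and compound 4 cannot be read, so those two compounds cannot be ordered: the limit of > 3.7 in this assay, at which 2 of the 4 values shown sit.

As far as these compounds go, the actual number for compound 4 stays open, and so does the question of which part of the change matters more, the hetero atom of the ring or the methyl link that now stands between the ring and the amide-type nitrogen. A benzyl group on the same nitrogen would help to separate these two parts, and a (pyridin-3-yl)methyl group would test where the ring hetero atom sits.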